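Removing the Chloro: Expectation for Compound 4

The compounds below may be only part of what the source reports. "The series", "measured", "known", "first", "only" and "open" are said of these compounds alone.

Compound 1 `COc1ccccc1/C=N/Nc1nc2ccccc2nc1Cc1ccccc1` gives 83 nM in an assay on isolated protein for inhibition of Amine oxidase [flavin-containing] A (Homo sapiens), read by spectrophotometry; on this read-out higher numbers stand for weaker inhibition and lower numbers for stronger inhibition.
Compound 2 `C(=N/Nc1nc2ccccc2nc1Cc1ccccc1)\c1ccccc1` gives 81 nM in this assay.
Compound 3 `Clc1ccccc1/C=N/Nc1nc2ccccc2nc1Cc1ccccc1` gives 5.8 nM in this assay.

Compound 3 gives the lowest number of the three, and the others stand well away from it: a 14-fold lower number from compound 1 to compound 3 (1.16 log units; beyond the scatter) and a 14-fold lower number from compound 2 to compound 3 (1.15 log units; beyond the scatter). Compound 4 `Oc1ccc(/C=N/Nc2nc3ccccc3nc2Cc2ccccc2)cc1` has not been measured; it differs from compound 3 in one place: 4-hydroxyphenyl in place of 2-chlorophenyl on a carbon with a double bond to nitrogen. Going by the values given here, the steps that bear on this are a 14-fold lower number from compound 1 to compound 3 (1.16 log units; beyond the scatter) and a 14-fold lower number from compound 2 to compound 3 (1.15 log units; beyond the scatter), both large and both tied to bringing in chloro, while a 1.0-fold lower number from compound 1 to compound 2 (0.01 log units; within the scatter) shows methoxy and hydrogen giving indistinguishable numbers. Since compound 4 gives up the chloro, the expected step is a 13-fold higher number from compound 3 to compound 4 (1.11 log units; beyond the scatter), back toward the numbers of compound 1 and compound 2. Compound 4 is therefore estimated at 75 nM, in the range 20 nM to 280 nM.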

Compound 4, half-maximal inhibitory concentration: 3.4 nM
For compound 4 the middle estimate is 22-fold (1.34 log units) above the measured one, and the stated range ends above it.
By their numbers in this assay, from the lowest: compounds 4 and 3 (each within the scatter of the next); then compounds 2 and 1 (each within the scatter of the next).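

In this assay a low number at this place does not depend on chloro: with 4-hydroxyphenyl in place of 2-chlorophenyl there is a 1.7-fold lower number from compound 3 to compound 4 (0.23 log units; within the scatter) and the two compounds cannot be told apart. The hydroxy compound also stands well clear of the compounds without chloro, with a 24-fold lower number from compound 2 to compound 4 (1.38 log units; beyond the scatter) and a 24-fold lower number from compound 1 to compound 4 (1.39 log units; beyond the scatter) as large steps. Nothing measured here explains why these two different groups give such similar numbers.

This single swap changes both the group and its place on the ring, so those two effects remain unseparated. On these data alone, whether an amine or a carboxylic acid in place of the hydroxy would also give a number this low remains open.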